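From compound 2 to compound 3: working notes

A few compounds are considered here, and "the series" means these few. Any claim that something is new, unique, unknown or untested is made for them only; others in the source may bear on it.

Measured so far in a physicochemical assay for solubility, using the shake flask method, measured as kinetic solubility, with a stated time of 2 h, at pH 7.4; a higher number here means a more soluble compound, a lower number a less soluble compound
- Compound 1 `O=C(Nc1ccccc1)c1cc(NCc2ccccc2)ncn1` gives < 5000 nM as a limit
- Compound 2 `CN(c1ccccc1)c1cc(C(=O)Nc2ccccc2)ncn1` gives < 5000 nM as a limit

Compound 2 has no number, only a limit, and the same holds for compound 1. For the measured compounds named here, all the series offers so far is the limit of < 5000 nM in this assay, at which 2 of the 2 values shown sit, and no step between measured compounds. Compound 3 `CN(Cc1ccccc1Cl)c1cc(C(=O)Nc2ccccc2)ncn1` carries 2-chlorobenzyl in place of the phenyl of compound 2, on a nitrogen on an aromatic ring, and the difference counts as 2-chlorobenzyl in place of phenyl on a nitrogen on an aromatic ring with the rest of the shared core unchanged. Going by the values given here, no measured step is available to guide this swap, so no change beyond the usual scatter is expected in this assay here. The estimated move is a step that the limit leaves unreadable from compound 2 to compound 3 and it is expected to stay small. For compound 3 the expected value is 2500 nM with an estimated range from 600 nM to 5000 nM and another report as a limit is likely.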

Compound 3, solubility: < 5000 nM
Compound 3 gave a limit, no number; the forecaster's own chance of this, stated with the estimate: 70%; the middle value is on the limit's open side.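

Compound 2 and compound 3 are both reported only as limits in this assay and no step between them can be read, with the series so far resting on one limit: the limit of < 5000 nM in this assay, at which 3 of the 3 values shown sit.
The compounds shown leave open what numbers compound 2 and compound 3 would give in this assay and whether 2-chlorobenzyl in place of phenyl changes the read-out at all.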